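A few compounds are considered here, and "the series" means these few. Any claim that something is new, unique, unknown or untested is made for them only; others in the source may bear on it.

Values in a functional assay on A-375 cells (Homo sapiens) for inhibition, read by CCK-8 assay, with a stated time of 72 h, tested at 2 uM; a lower number here means less inhibition of growth, a higher number more inhibition of growth at the concentration tested:
- compound 1 `COc1ccc(SCc2ccc(/C=C/C(=O)Nc3ccccc3N)cc2)cc1OC`: 46%
- compound 2 `COc1ccc(SCc2ccc(C(=O)Nc3ccccc3N)cc2)cc1`: 10.2%
- compound 3 `CCc1ccc(SCc2ccc(C(=O)Nc3ccccc3N)cc2)cc1`: 19.6%

In this assay compound 3 gives 19.6%, which lies within the scatter of compound 2 at 10.2%. Compound 1 stands at 46%, a gap to compound 3 that is beyond the scatter.

The next structure is compound 4 `Nc1ccccc1NC(=O)c1ccc(CSc2cccc(F)c2)cc1`, which has 3-fluorophenyl in place of 4-ethylphenyl on a sulfur. Going by the values given here, only one measured step bears on this change. It concerns the same aromatic ring, where ethyl in place of methoxy on an aromatic carbon gave a number 9.4 percentage points higher from compound 2 to compound 3 (within the scatter), a step within the scatter. Among the compounds with values here, no fluorine-bearing compound has been measured, so the evidence is thin, and compound 1 differs from the others in more than one place and offers no step.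

No change beyond the scatter is therefore expected. The expected change is a number 3.6 percentage points lower from compound 3 to compound 4 (within the scatter). For compound 4 the estimate is 16%, with an expected range from 6% to 30%.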

Compound 4, percent growth inhibition at one concentration: 37.7%
For compound 4 the middle estimate is 21.7 percentage points below the measured one, outside the stated range (above it).
By their numbers in this assay, from the lowest: compounds 2 and 3 (each within the scatter of the next); then compounds 4 and 1 (each within the scatter of the next).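

In this assay, the group on the sulfur turns out to be able to shift growth inhibition beyond the scatter: 3-fluorophenyl in place of 4-ethylphenyl gives a number 18.1 percentage points higher from compound 3 to compound 4 (beyond the scatter), and 3-fluorophenyl in place of 4-methoxyphenyl gives a number 27.5 percentage points higher from compound 2 to compound 4 (beyond the scatter). The earlier change on this ring, a number 9.4 percentage points higher from compound 2 to compound 3 (within the scatter), had shown no such shift, and so gave no sign that this place could respond so clearly. Nothing measured here speaks to why the number rose.

Both new steps change the substituent and its place on the ring together, and the compounds shown cannot tell these two changes apart. Going by these compounds, it remains open how a 4-fluorophenyl or a 3-methoxyphenyl group on the sulfur would compare with the 3-fluorophenyl group of compound 4.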